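Carboxy to amide variations on the shared core

The source may report more compounds than this note shows. Statements on the series, on what has been measured and on what is new or still open speak of the compounds shown alone.

Compound 1 `COc1cc2c(cc1OC)C(CC(=O)O)CC2` carries a carboxy group on its side chain. In a functional assay on the whole organism (strain Wistar) for inhibition, with Rattus norvegicus as the target, read by paw edema, with stated times of 60 min and 24 h, at a dose of 100 mg/kg by the oral route (a lower number here means less inhibition, a higher number more inhibition at the dose given (going by the name of the read-out)), compound 1 gives 26.7%. Compound 2 `COc1cc2c(cc1OC)C(CC(N)=O)CC2` gives 26.7% in the same assay, and compound 3 `COc1cc2c(cc1OC)C(CC(=O)N(C)C)CC2` gives 23.3%. On these numbers compound 1 stands level with compound 2 at the digits shown; compound 3 is the furthest of the three from it, yet all three values lie within the usual scatter of one another.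

The measured steps are small throughout: no change at the digits printed from compound 1 to compound 2 (within the scatter), a number 3.4 percentage points lower from compound 1 to compound 3 (within the scatter) and a number 3.4 percentage points lower from compound 2 to compound 3 (within the scatter). Neither replacing hydroxy by amino nor by dimethylamino on the carbonyl carbon moved the read-out beyond the scatter.

Compound 4 `CCN(CC)C(=O)CC1CCc2cc(OC)c(OC)cc21` differs from compound 1 as follows: diethylamino in place of hydroxy on a carbonyl carbon. Within the data shown here, the steps that bear on this are the two other replacements of hydroxy on the same carbonyl carbon, no change at the digits printed from compound 1 to compound 2 (within the scatter) and a number 3.4 percentage points lower from compound 1 to compound 3 (within the scatter), both within the scatter. Diethylamino is a further amide of the same kind, so no step beyond the scatter is expected in this assay.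

Compound 4 is therefore estimated at 24%, with a range of 12% to 36%, which corresponds to an expected step of a number 2.7 percentage points lower from compound 1 to compound 4 (within the scatter).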

Compound 4, a percentage reported as inhibition, in the whole organism at one dose (the size of the read-out at that dose, not a potency): 16.7%
Compound 4: the middle estimate sits 7.3 percentage points above what was measured; low and high end bracket the measured number.
By their numbers in this assay, from the lowest: compounds 4, 3, 1 and 2 (each within the scatter of the next).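

In this assay diethylamino on the carbonyl carbon gives a number 10 percentage points lower from compound 1 to compound 4 (within the scatter) and a number 10 percentage points lower from compound 2 to compound 4 (within the scatter) together with a number 6.6 percentage points lower from compound 3 to compound 4 (within the scatter) and thereby adds a larger amide group to the comparison at this place. The first two of these are the largest steps printed for the series, yet each remains within the scatter, so even the change from carboxy to diethylcarbamoyl does not separate compound 4 from compounds 1, 2 and 3 and the four compounds cannot be ranked at this single dose. No measurement at hand accounts for these numbers.

What the compounds shown leave open is whether a longer chain on the amide nitrogen, such as dipropylamino, would give a step beyond the scatter from compound 1. Also open, from the compounds shown here alone, is how a methyl ester on the same carbonyl carbon would compare with the carboxy group of compound 1 in this read-out, and whether any change at this place matters at a dose other than the one tested.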